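Chloro on the core of compound 3: expected inhibition

The source may report more compounds than this note shows. Statements on the series, on what has been measured and on what is new or still open speak of the compounds shown alone.

Measured in a functional assay on K562 cells (Homo sapiens) for inhibition, read by thymidine incorporation, with a stated time of 48 h, tested at 10 ug/mL (on this read-out lower numbers stand for less inhibition and higher numbers for more inhibition at the one concentration tested (going by the name of the read-out)), so far:
Compound 1 `Clc1nc(C#Cc2ccccc2)c2ncn(Cc3ccccc3)c2n1`: 100%
Compound 2 `C(=C/c1ncnc2c1ncn2C1CCOCC1)\c1ccccc1`: 66%
Compound 3 `C(=C/c1ncnc2c1ncn2Cc1ccccc1)\c1ccccc1`: 93%

Compound 3 stands second highest of the three numbers. Within the data shown here, compound 1 is within the scatter of it, and compound 2 lies beyond the scatter below it, the only measured step being a number 27 percentage points higher from compound 2 to compound 3 (beyond the scatter), a change on the aromatic nitrogen. Compound 4 `Clc1nc(/C=C/c2ccccc2)c2ncn(Cc3ccccc3)c2n1` carries chloro in place of hydrogen on an aromatic carbon. Among the measured compounds shown here, no measured step touches this change; compound 1 differs from compound 3 in two places, so its value only shows that a chloro-bearing member reaches a high number. The expected step in this assay is therefore a number 2 percentage points higher from compound 3 to compound 4 (within the scatter), not beyond the scatter. Compound 4 is estimated at 95%, between 80% and 100%.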

Compound 4, a percentage reported as inhibition, at one concentration (the size of the read-out at that concentration, not a potency): 99%
The estimate for compound 4 lay 4 percentage points below the measured number, and the stated range covers the measured number.
By their numbers in this assay, from the lowest: compound 2; then compounds 3, 4 and 1 (each within the scatter of the next).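

In this assay, chloro in place of hydrogen on the aromatic carbon between two ring nitrogen atoms gives a number 6 percentage points higher from compound 3 to compound 4 (within the scatter), so this position accepts chloro, although compound 3 already stands at 93% and leaves little room to show a gain. With chloro present, 2-phenylethenyl in place of 2-phenylethynyl gives a number 1 percentage points lower from compound 1 to compound 4 (within the scatter), so this read-out does not separate these two groups. No evidence bears on either result.

Going by these compounds, whether an amine or a methoxy group on this carbon would hold the number remains open. Also open, on these data alone, is whether chloro would shift a lower-reading member such as compound 2, which carries oxan-4-yl.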